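The compounds below may be only part of what the source reports. "The series", "measured", "known", "first", "only" and "open" are said of these compounds alone.

Compound 3 `COc1cc(-c2nnc(SCc3ccccc3)n2N2C(=O)c3ccccc3C2=O)cc(OC)c1OC` reaches only a limit in a functional assay on PC-3M cells (Homo sapiens) for cytotoxicity, read by MTT assay, with a stated time of 48 h (on this read-out higher numbers stand for weaker inhibition and lower numbers for stronger inhibition), namely > 200000 nM. Compound 1 `C=CCSc1nnc(-c2cc(OC)c(OC)c(OC)c2)n1N1C(=O)c2ccccc2C1=O` also sits at a limit in this assay, > 200000 nM. Compound 2 `COc1cc(-c2nnc(SCC(=O)c3ccc(C)cc3)n2N2C(=O)c3ccccc3C2=O)cc(OC)c1OC`, by contrast, gives 11700 nM in this assay, so that the step of an at least 17-fold higher number from compound 2 to compound 3 (1.23 log units; beyond the scatter) and the step of an at least 17-fold lower number from compound 1 to compound 2 (1.23 log units; beyond the scatter) were both large, with the limit of > 200000 nM in this assay, at which 2 of the 3 values shown sit, marking where the other two values rest. Compound 4 `COc1ccc(C(=O)CSc2nnc(-c3cc(OC)c(OC)c(OC)c3)n2N2C(=O)c3ccccc3C2=O)cc1` carries (4-methoxyphenyl)carbonyl in place of phenyl on a saturated chain carbon bound to a sulfur. Among the measured compounds shown here, this change resembles the one that separates compound 2 from compound 3, and because an at least 17-fold higher number from compound 2 to compound 3 (1.23 log units; beyond the scatter) was large, a large lowering step is anticipated here. Compound 4 is estimated at 12000 nM in this assay, within a range from 3000 nM to 60000 nM. The expected step is an at least 16-fold lower number from compound 3 to compound 4 (1.22 log units; beyond the scatter).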

Compound 4, half-maximal inhibitory concentration: 32800 nM
Beside the measured number, compound 4's estimate is 2.7-fold (0.44 log units) below it; low and high end bracket the measured number.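

In this assay, with (4-methoxyphenyl)carbonyl on the saturated chain carbon bound to a sulfur, an at least 6.0-fold lower number from compound 3 to compound 4 (0.78 log units; beyond the scatter) and an at least 6.0-fold lower number from compound 1 to compound 4 (0.78 log units; beyond the scatter) show that the drop seen with (4-methylphenyl)carbonyl is not confined to that one group. The choice of aromatic substituent still registers, since methoxy in place of methyl on an aromatic carbon gives a 2.8-fold higher number from compound 2 to compound 4 (0.45 log units; beyond the scatter) at this position. Both of the first two steps start from a limit: the limit of > 200000 nM in this assay, at which 2 of the 4 values shown sit.

As far as these compounds go, whether an amine or a carboxylic acid in place of methoxy would keep the number low stays open. So does whether a carbonyl on a plain alkyl chain, without the aromatic ring, would suffice.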